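A cyclohexylamino group on the sulfonyl sulfur of compound 3

This account rests on a few compounds, and the source may have more. Where it says the series, first, only, none or still open, it means among the compounds named here.

In an ADME assay on Vero cells (Chlorocebus sabaeus) for cytotoxicity, read by MTT assay (on this read-out higher numbers stand for lower toxicity in this test and lower numbers for higher toxicity in this test), compound 1 `CCn1nc(C(F)(F)F)cc1C(=O)Nc1ccc(S(=O)(=O)N2CCCCC2C)cc1` gives 30000 nM and compound 3 `Cn1nc(C(F)(F)F)cc1C(=O)Nc1ccc(S(=O)(=O)N2CCCCCCC2)cc1` gives 16000 nM, two numbers within the scatter of each other. Among the measured compounds shown here, compound 2 `COC(=O)c1ccccc1-n1nc(C(F)(F)F)cc1C(=O)Nc1ccc(S(=O)(=O)N2CCCC2)cc1` is recorded as "not determined" (no result reported), so compound 3 stands level with the only other number available. Compound 4 `Cn1nc(C(F)(F)F)cc1C(=O)Nc1ccc(S(=O)(=O)NC2CCCCC2)cc1` differs from compound 3 by a group of 7 heavy atoms (6 carbon, 1 nitrogen; one six-membered non-aromatic ring of carbon only) in place of a group of 8 heavy atoms (7 carbon, 1 nitrogen; one eight-membered non-aromatic ring with 1 hetero atom), on a sulfonyl sulfur, on a sulfonyl sulfur. For the measured compounds named here, no step between measured compounds shows what such a change does in this assay. The expectation therefore rests on compound 3 at 16000 nM, and no shift beyond the scatter is foreseen in either direction. The estimated step of a 1.3-fold higher number from compound 3 to compound 4 (0.10 log units; within the scatter) is correspondingly small. Compound 4 is expected at 20000 nM, with an estimated range from 8000 nM to 50000 nM.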

Compound 4, half-maximal cytotoxic concentration: 15000 nM
Compound 4: the middle estimate sits 1.3-fold (0.12 log units) above what was measured, within the range that was stated.
By their numbers in this assay, from the lowest: compounds 4, 3 and 1 (each within the scatter of the next).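

Among the compounds shown here, the pair gives the first reading of a change on the sulfonyl sulfur: in this assay, cyclohexylamino in place of the eight-membered ring gives a 1.1-fold lower number from compound 3 to compound 4 (0.03 log units; within the scatter) on an otherwise unchanged core. This exchange of ring and attachment therefore leaves the read-out within the scatter. Nothing measured here bears on why this is so.

As far as these compounds go, whether a carboxylic acid or an amine on the cyclohexyl ring, or an open butylamino chain on the sulfonyl sulfur, would read differently stays open. Compound 1 and compound 2 differ from this pair in more than one place, so they cannot settle it.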